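From Compound 1 to Compound 4: Adding Trifluoromethyl

The source may hold more compounds than are shown below. What is called first, only, known or untested is meant among the compounds shown, and "the series" means these compounds.

In a functional assay on T-24 cells (Homo sapiens) for antiproliferative activity, read by MTT assay, with a stated time of 48 h (on this read-out higher numbers stand for weaker inhibition and lower numbers for stronger inhibition), compound 1 `O=C(Nc1ccccc1)Nc1cccc(CNc2nccnc2Cl)c1` gives 19800 nM, the higher of the two numbers available. Compound 3 `O=C(Nc1cccc(CNc2nccnc2Cl)c1)Nc1ccccc1F` gives 7450 nM. Compound 2 `O=C(Nc1cccc(CNc2nccnc2Cl)c1)NC1CCCC1` reads > 40000 nM, which is a limit of the assay and not a number. Compound 4 `O=C(Nc1cccc(CNc2nccnc2Cl)c1)Nc1cccc(C(F)(F)F)c1` has not yet been measured; it carries trifluoromethyl in place of hydrogen on an aromatic carbon, (trifluoromethyl in place of hydrogen on an aromatic carbon).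

The closest measured change is fluoro in place of hydrogen on an aromatic carbon, which gave a 2.7-fold lower number from compound 1 to compound 3 (0.42 log units; beyond the scatter). Cyclopentyl in place of phenyl gave an at least 2.0-fold higher number from compound 1 to compound 2 (0.30 log units; that floor lies within the scatter), and 2-fluorophenyl in place of cyclopentyl gave an at least 5.3-fold lower number from compound 2 to compound 3 (0.72 log units; beyond the scatter), but both alter the whole group on the amide-type nitrogen and bear only indirectly. With a single close precedent, a 2.7-fold lower number from compound 1 to compound 3 (0.42 log units; beyond the scatter), a modest move to a lower number is expected in this assay. The expected change is a 2.2-fold lower number from compound 1 to compound 4 (0.34 log units; beyond the scatter). For compound 4 the estimated value is 9000 nM, with an expected range of 3000 nM to 25000 nM.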

Compound 4, half-maximal inhibitory concentration: 5080 nM
Beside the measured number, compound 4's estimate is 1.8-fold (0.25 log units) above it; the measured number falls inside the stated range.
By their numbers in this assay, from the lowest: compounds 4 and 3 (each within the scatter of the next); then compound 1. At a limit, above all of these: compound 2.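

In this assay, trifluoromethyl on an aromatic carbon, meta to a large group, gives a 3.9-fold lower number from compound 1 to compound 4 (0.59 log units; beyond the scatter). Until now the only substituent shown on this ring was fluoro, with a 2.7-fold lower number from compound 1 to compound 3 (0.42 log units; beyond the scatter), so the earlier compounds could not show whether a larger group would be tolerated there. Compound 4 shows that a group of 4 heavy atoms on this six-membered aromatic ring still moves the number down from that of compound 1, and no compound shown with a substituent on this ring goes against that direction.

The compounds shown do not separate the effect of the group from that of its place on the ring, and they leave open how a methoxy group, an amine or a carboxylic acid would read there. Nothing measured here accounts for the lower number of compound 4.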